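Alpha-branched amino acyl variants of a chlorobenzamide piperidine series

This account rests on a few compounds, and the source may have more. Where it says the series, first, only, none or still open, it means among the compounds named here.

Compound 1, `CCCC(N)C(=O)N1CCC(CN2CCC(NC(=O)c3cc(Cl)c(N)cc3OC)CC2)CC1`, gives 2.57 nM in an assay on striatum for inhibition of 5-hydroxytryptamine receptor 4 (Cavia porcellus), read by radioligand binding; on this read-out lower numbers stand for stronger inhibition and higher numbers for weaker inhibition.
Compound 2, `COc1cc(N)c(Cl)cc1C(=O)NC1CCN(CC2CCN(C(=O)C(C)N)CC2)CC1`, gives 5.06 nM in this assay.
Compound 3, `COc1cc(N)c(Cl)cc1C(=O)NC1CCN(CC2CCN(C(=O)CCCCN)CC2)CC1`, gives 3.91 nM in this assay.

Compound 3 stands second highest of the three numbers; its nearest neighbour is compound 2, with a 1.3-fold lower number from compound 2 to compound 3 (0.11 log units; within the scatter), and the furthest is compound 1, with a 1.5-fold higher number from compound 1 to compound 3 (0.18 log units; within the scatter). Both of these steps, like a 2.0-fold higher number from compound 1 to compound 2 (0.29 log units; within the scatter), fall within the scatter, so the three measured compounds cannot be told apart on this read-out.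

Compound 4, `COc1cc(N)c(Cl)cc1C(=O)NC1CCN(CC2CCN(C(=O)C(C)(C)N)CC2)CC1`, has not yet been measured in this assay. It differs from compound 3 as follows: 1-amino-1-methylethyl in place of 4-aminobutyl on a carbonyl carbon. Among the measured compounds shown here, the measured steps that bear on this change are those between the three amino acyl groups already in hand, a 2.0-fold higher number from compound 1 to compound 2 (0.29 log units; within the scatter), a 1.5-fold higher number from compound 1 to compound 3 (0.18 log units; within the scatter) and a 1.3-fold lower number from compound 2 to compound 3 (0.11 log units; within the scatter), none of which reaches beyond the scatter; the series gives no precedent for two methyl groups on the carbon that carries the amine. On that basis compound 4 is expected to show no step beyond the scatter, estimated as a 1.3-fold higher number from compound 3 to compound 4 (0.11 log units; within the scatter). Compound 4 is therefore estimated at 5 nM in this assay, with a range from 1.8 nM to 14 nM.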

Compound 4, half-maximal inhibitory concentration: 2.6 nM
Compound 4: the middle estimate sits 1.9-fold (0.28 log units) above what was measured, and the stated range covers the measured number.
By their numbers in this assay, from the lowest: compounds 1, 4, 3 and 2 (each within the scatter of the next).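

In this assay, among the compounds shown here, 1-amino-1-methylethyl on the carbonyl carbon is the first group with no hydrogen on the chain carbon bound to the amine nitrogen, yet it stays within the scatter of each of the other three compounds: the exchange for 4-aminobutyl gives a 1.5-fold lower number from compound 3 to compound 4 (0.18 log units; within the scatter), methyl in place of hydrogen on that chain carbon gives a 1.9-fold lower number from compound 2 to compound 4 (0.29 log units; within the scatter), and the exchange for 1-aminobutyl gives a 1.0-fold higher number from compound 1 to compound 4 (0.01 log units; within the scatter). This place has now carried 1-aminobutyl, 1-aminoethyl, 4-aminobutyl and 1-amino-1-methylethyl with no step beyond the scatter, so the four compounds cannot be told apart on this read-out, and the tolerance seen among the earlier three now extends to a second methyl on that carbon. No measurement of any other kind is at hand that bears on this result.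

The compounds shown leave open whether any group at this place would give a step beyond the scatter, for instance a carboxylic acid in place of the amine or a chain longer than 4-aminobutyl. On these data alone, whether the amine matters at all also stays open, as these compounds cannot tell how a plain acetyl group would read on this carbonyl carbon.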